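Compound 3 to compound 4: a ring swap under test

The compounds below may be only part of what the source reports. "The series", "measured", "known", "first", "only" and "open" are said of these compounds alone.

Measured so far in an in vivo ADME assay on the whole organism (strain 129/SvEvBrd x C57BL/6) for pharmacokinetics, with Mus musculus as the target; a lower number here means that a smaller share of the oral dose reaches the circulation, a higher number that a larger share of the oral dose reaches the circulation:
- compound 1 `CN(C)C(=O)c1nc([C@@H](O)[C@H](O)[C@H](O)CO)c[nH]1`: 5%
- compound 2 `Cc1nc(-c2nc([C@@H](O)[C@H](O)[C@H](O)CO)c[nH]2)cs1`: 23%
- compound 3 `OC[C@@H](O)[C@@H](O)[C@H](O)c1c[nH]c(-c2ncccn2)n1`: 7%

The three compounds share one core and differ only in the group on an aromatic carbon. In this assay, compound 3 at 7% cannot be told apart from compound 1 at 5%, while the swap to the group of compound 3 from that of compound 2 gave a number 16 percentage points lower from compound 2 to compound 3 (beyond the scatter).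

The next compound, compound 4 `OC[C@@H](O)[C@@H](O)[C@H](O)c1c[nH]c(-c2ncon2)n1`, has 1,2,4-oxadiazol-3-yl in place of pyrimidin-2-yl on that same carbon: 1,2,4-oxadiazol-3-yl in place of pyrimidin-2-yl on an aromatic carbon. A six-membered aromatic ring leaves and a five-membered one enters.

Two other measured swaps at this carbon bear on the question. Putting in pyrimidin-2-yl for dimethylcarbamoyl gave a number 2 percentage points higher from compound 1 to compound 3 (within the scatter), whereas 2-methyl-1,3-thiazol-4-yl for dimethylcarbamoyl gave a number 18 percentage points higher from compound 1 to compound 2 (beyond the scatter). So swaps here have been both silent and modest. The entering group is a five-membered aromatic ring, as in compound 2 at 23%, which suggests a slight lean upward, but three compounds give only weak guidance. The expected change is small, a number 5 percentage points higher from compound 3 to compound 4 (within the scatter). For compound 4 the estimated value is 12%, with an expected range from 3% to 28%.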

Compound 4, oral bioavailability: 5%
The estimate for compound 4 lay 7 percentage points above the measured number; the measured number falls inside the stated range.
By their numbers in this assay, from the lowest: compounds 1, 4 and 3 (each within the scatter of the next); then compound 2.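

In this assay, 1,2,4-oxadiazol-3-yl in place of pyrimidin-2-yl gave a number 2 percentage points lower from compound 3 to compound 4 (within the scatter), and the same ring in place of dimethylcarbamoyl gave no change at the digits printed from compound 1 to compound 4 (within the scatter), so three quite different groups on this carbon now cannot be told apart. A five-membered aromatic ring is therefore not enough on its own to reach the level of compound 2: 1,2,4-oxadiazol-3-yl in place of 2-methyl-1,3-thiazol-4-yl gave a number 18 percentage points lower from compound 2 to compound 4 (beyond the scatter), which leaves compound 2 as the only one of the four set apart from the others. Nothing measured on these compounds accounts for that gap.

The rings of compound 2 and compound 4 differ in their ring atoms and also in the methyl group, so these compounds cannot show which of the two matters, and a 1,3-thiazol-4-yl ring without its methyl, or the oxadiazole ring carrying a methyl, would separate them. Also open, as far as these compounds go, is how a quite different kind of group on this carbon, such as an amine or a carboxylic acid, would behave on the shared core.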